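Ring Size Swap at the Amide Carbonyl of Compound 1

The compounds below may be only part of what the source reports. "The series", "measured", "known", "first", "only" and "open" are said of these compounds alone.

Measured compounds in a functional assay on A2780 cells (Homo sapiens) for antiproliferative activity, read by fluorescence, with a stated time of 72 h; a lower number here means a stronger inhibitor, a higher number a weaker inhibitor:
compound 1 `CN1CCC(C(=O)N2Cc3c(NC(=O)C4CCC4)n[nH]c3C2(C)C)CC1`, 140 nM
compound 2 `CN1CCC(C(=O)N2Cc3c(NC(=O)c4ccccc4)n[nH]c3C2(C)C)CC1`, 160 nM
compound 3 `CN1CCC(C(=O)N2Cc3c(NC(=O)c4cccs4)n[nH]c3C2(C)C)CC1`, 30 nM

Compound 1 carries a cyclobutyl on the carbonyl carbon of the amide attached to the shared core. Among the three numbers in this assay, compound 1 sits close to compound 2 and apart from compound 3: the step of a 1.1-fold higher number from compound 1 to compound 2 (0.06 log units; within the scatter) lies within the scatter, whereas the steps of a 4.7-fold lower number from compound 1 to compound 3 (0.67 log units; beyond the scatter) and a 5.3-fold lower number from compound 2 to compound 3 (0.73 log units; beyond the scatter) lie beyond it.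

Compound 4 `CN1CCC(C(=O)N2Cc3c(NC(=O)C4CC4)n[nH]c3C2(C)C)CC1` differs from compound 1 in one place: cyclopropyl in place of cyclobutyl on a carbonyl carbon.

Going by the values given here, none of the measured steps exchanges one small non-aromatic ring for another, so no step bears directly on this change. The closest guide is the step of a 1.1-fold higher number from compound 1 to compound 2 (0.06 log units; within the scatter), where phenyl in place of cyclobutyl on the carbonyl carbon left the number within the scatter; the gain seen in compound 3 came with thiophen-2-yl, not with a change of ring size. Compound 4 is therefore expected to stay near compound 1, with a step of a 1.1-fold higher number from compound 1 to compound 4 (0.03 log units; within the scatter) that falls within the scatter. The estimate for compound 4 in this assay is 150 nM, with a range from 60 nM to 380 nM.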

Compound 4, half-maximal inhibitory concentration: 1420 nM
For compound 4 the middle estimate is 9.5-fold (0.98 log units) below the measured one; measured number outside the range, above it.
By their numbers in this assay, from the lowest: compound 3; then compounds 1 and 2 (each within the scatter of the next); then compound 4.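

In this assay this position proved sensitive to the identity of a small non-aromatic ring: cyclopropyl in place of cyclobutyl on the carbonyl carbon gives a 10-fold higher number from compound 1 to compound 4 (1.01 log units; beyond the scatter), although phenyl and cyclobutyl had stayed within the scatter of each other. Compound 4 is also set apart from both aromatic amides, with an 8.9-fold higher number from compound 2 to compound 4 (0.95 log units; beyond the scatter) and a 47-fold higher number from compound 3 to compound 4 (1.68 log units; beyond the scatter), so the earlier flat step from cyclobutyl to phenyl did not mean that this position tolerates any ring. Nothing in the data given accounts for this loss.

The compounds shown leave open whether cyclopentyl or an open chain such as isopropyl would stand with cyclobutyl or with cyclopropyl. They also leave open whether the low number of compound 3 extends to furan-2-yl.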